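Bromo for methyl on the phenol ring of compound 1

A few compounds are considered here, and "the series" means these few. Any claim that something is new, unique, unknown or untested is made for them only; others in the source may bear on it.

Measured so far in a functional assay for binding affinity to metabotropic glutamate receptor 2 (Homo sapiens), read by GTPgammaS binding; on this read-out lower numbers stand for an effect already at smaller amounts and higher numbers for an effect only at larger amounts of compound:
compound 1 `Cc1c(OCCCCOc2ccccc2)ccc(C(=O)CC(C)C)c1O` gives 4550 nM
compound 2 `Cc1c(OCCCCOc2cccc(F)c2F)ccc(C(=O)CC(C)C)c1O` gives 384 nM

Compound 1 has the highest of the two numbers; its nearest neighbour is compound 2, separated by a 12-fold lower number from compound 1 to compound 2 (1.07 log units; beyond the scatter). Among the measured compounds shown here, that single step concerns the aryl ether end of the chain and is the only comparison available.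

Compound 3 `CC(C)CC(=O)c1ccc(OCCCCOc2ccccc2)c(Br)c1O` differs from compound 1 by bromo in place of methyl on an aromatic carbon. For the measured compounds named here, no measured pair touches this position, so the one known step gives no direct reading on the change, and there is nothing to indicate a shift in either direction. In the absence of bearing data, a step within the usual scatter is the expectation, with the estimate centred on the value of compound 1 and given a wide range to reflect the lack of precedent.

For compound 3, the expected value in this assay is 3500 nM (range 1200 nM to 12000 nM), which is expected to amount to a 1.3-fold lower number from compound 1 to compound 3 (0.11 log units; within the scatter).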

Compound 3, half-maximal effective concentration: 1500 nM
Compound 3: the middle estimate sits 2.3-fold (0.37 log units) above what was measured; low and high end bracket the measured number.
By their numbers in this assay, from the lowest: compound 2; then compound 3; then compound 1.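

In this assay, the aromatic carbon ortho to a hydroxy group gives its first reading: bromo in place of methyl brings a 3.0-fold lower number from compound 1 to compound 3 (0.48 log units; beyond the scatter), a modest step but one beyond the usual scatter. The methyl is therefore not required at this place for the effect seen with the phenyl end of the chain, and a bromo is tolerated there with a lower number. No measured data on the compounds bear on why the number moves.

Going by these compounds, whether this step and the 2,3-difluorophenyl change add up when both are combined in one compound remains open. Also open, on these data alone, is whether chloro, hydrogen or a nitrile at this place would shift the number in the same direction as bromo, so a single replacement gives no trend for the position.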